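A Methyl-to-Fluoro Swap Among Compounds at the Limit

The source may hold more compounds than are shown below. What is called first, only, known or untested is meant among the compounds shown, and "the series" means these compounds.

Of the compounds shown here, three sharing one core have been measured in an ADME assay on MCF-10A cells (Homo sapiens) for inhibition, with a stated time of 48 h (on this read-out higher numbers stand for weaker inhibition and lower numbers for stronger inhibition), so far. Compound 1 (`Cc1ccccc1-c1noc([C@@H]2CCCN2C(=O)Nc2ccc(Cl)cc2)n1`) gives > 50000 nM as a limit of the assay and not a number. Compound 2 (`O=C(Nc1ccc(Cl)cc1)N1CCC[C@H]1c1nc(-c2ccccc2F)no1`) gives > 50000 nM as a limit as well. Compound 3 (`Cc1cccc(-c2noc([C@@H]3CCCN3C(=O)Nc3ccc(Cl)cc3)n2)c1`) gives > 50000 nM as a limit too. That places compound 3 at the limit of > 50000 nM in this assay, at which 3 of the 3 values shown sit, with no order readable among the three.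

The next compound, compound 4 (`O=C(Nc1ccc(Cl)cc1)N1CCC[C@H]1c1nc(-c2cccc(F)c2)no1`), departs from compound 3 by one substitution (fluoro in place of methyl on an aromatic carbon) with fluoro in place of methyl on an aromatic carbon, meta to a large group, so that 3-methylphenyl becomes 3-fluorophenyl. Among the compounds with values here, the closest precedent is a step that the two limits leave unreadable from compound 1 to compound 2 where the same swap was made on the 2-substituted aryl group. The positional comparison a step that the two limits leave unreadable from compound 1 to compound 3 and the comparison a step that the two limits leave unreadable from compound 2 to compound 3 bear on it as well. None of these steps has a readable size, so none offers a magnitude to carry over, and no step beyond the scatter is expected in this assay on this evidence. The expected size is a number no higher from compound 3 to compound 4 (the limit leaves the size open) and no direction can be given for it. For compound 4 the estimated value is 50000 nM with an expected range from 30000 nM to 100000 nM and a report as a limit is the likeliest outcome.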

Compound 4, half-maximal inhibitory concentration: > 50000 nM
Compound 4 gave a limit, no number (the forecaster's own chance of this, stated with the estimate: 85%); the middle value lies on the limit itself.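

In this assay compound 4 gives > 50000 nM, which is a limit of the assay and not a number. Within the data shown here, no new step can therefore be read among compound 1, compound 2, compound 3 and compound 4. The compounds shown leave open any order among the four and the size of the swap from methyl to fluoro: the limit of > 50000 nM in this assay, at which 4 of the 4 values shown sit.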